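Aryl ketone swap on the furyl-bearing core

This account rests on a few compounds, and the source may have more. Where it says the series, first, only, none or still open, it means among the compounds named here.

Among the measured compounds shown here, compound 1 `COc1cc(-c2nnc3n2NC(c2ccco2)C(C(=O)c2ccc(F)cc2)S3)cc(OC)c1OC` is the only member of the series with a numbered result in a functional assay on A549 cells (Homo sapiens) for cytotoxicity, read by MTT assay, with a stated time of 48 h (on this read-out higher numbers stand for weaker inhibition and lower numbers for stronger inhibition), where compound 1 gives 53700 nM. Compound 2 `COc1cc(C(=O)C2Sc3nnc(-c4cc(OC)c(OC)c(OC)c4)n3NC2c2cccs2)cc(OC)c1OC` is also known; in this assay compound 2 reaches only the limit of > 100000 nM, a limit and not a number. That is the one further point on file for the assay (the limit of > 100000 nM in this assay, at which 1 of the 2 values shown sits). For the measured compounds named here, no step between two measured compounds can be read from this pair, since the two structures differ in more than one place.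

Compound 3 `COc1cccc(C(=O)C2Sc3nnc(-c4cc(OC)c(OC)c(OC)c4)n3NC2c2ccco2)c1` is not yet measured. Against compound 1 the change is 3-methoxyphenyl in place of 4-fluorophenyl on a carbonyl carbon. Going by the values given here, with no measured step to lean on, a change of this kind is expected to stay within the usual scatter, with no clear direction. The estimated step from compound 1 to compound 3 in this assay is a 1.1-fold higher number from compound 1 to compound 3 (0.05 log units; within the scatter). Compound 3 is accordingly estimated at 60000 nM, with a range from 20000 nM to 150000 nM.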

Compound 3, half-maximal inhibitory concentration: > 100000 nM
Compound 3: no number, only a limit; the forecaster's own chance of this, stated with the estimate: 35%; at least 1.6-fold (0.22 log units) between middle value and limit.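

Among the compounds shown here, the first readable step on this carbonyl carbon is 3-methoxyphenyl in place of 4-fluorophenyl, and in this assay it reads an at least 1.8-fold higher number from compound 1 to compound 3 (0.27 log units; that floor lies within the scatter). The value of compound 3 is a limit and not a number, which makes this step a floor only and leaves the true size of the change unknown. Compound 2 differs from compound 3 in more than one place and gives no readable step, and the series now rests largely on one limit: the limit of > 100000 nM in this assay, at which 2 of the 3 values shown sit.

Still open, on these data alone, is whether a 4-aminophenyl or 4-carboxyphenyl group on the same carbonyl carbon would give a numbered value in this assay. Also open, as far as these compounds go, is how a plain butyl chain at this place would compare with the 4-fluorophenyl of compound 1.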